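This account rests on a few compounds, and the source may have more. Where it says the series, first, only, none or still open, it means among the compounds named here.

Measured in a functional assay on HL-60 cells (Homo sapiens) for cytotoxicity, read by luminescence and CellTiter-Glo, with a stated time of 3 days; on this read-out lower numbers stand for stronger inhibition and higher numbers for weaker inhibition:
- compound 1 `Cc1ccc(C(=O)Nc2ccc(C#N)cc2)c(O)c1`: 2420 nM
- compound 2 `O=C(Nc1cc(C(F)(F)F)cc(C(F)(F)F)c1)c1ccc(-c2ccccc2)cc1O`: 1140 nM
- compound 3 `O=C(Nc1ccc(C(F)(F)F)cc1)c1ccc(Br)cc1O`: 360 nM

Compound 1 has the highest number of the three, and its gaps to compound 2 and compound 3 both lie beyond the scatter. Compound 4 `N#Cc1ccc(NC(=O)c2ccc(-c3ccncc3)cc2O)cc1` has pyridin-4-yl in place of methyl on an aromatic carbon, meta to a hydroxy group and para to a large group: pyridin-4-yl in place of methyl on an aromatic carbon. Within the data shown here, no measured pair isolates this change. Compound 2 carries a six-membered aromatic ring at that place and gives 1140 nM, but it also differs elsewhere, so it is only a loose guide. In this assay a small step to a lower number is expected, not clearly beyond the scatter. The expected step is a 1.9-fold lower number from compound 1 to compound 4 (0.27 log units; within the scatter). For compound 4 the estimate is 1300 nM, with an expected range of 350 nM to 4500 nM.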

Compound 4, half-maximal inhibitory concentration: 7090 nM
For compound 4 the middle estimate is 5.5-fold (0.74 log units) below the measured one; measured number outside the range, above it.
By their numbers in this assay, from the lowest: compound 3; then compound 2; then compound 1; then compound 4.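

In this assay, pyridin-4-yl in place of methyl on an aromatic carbon, meta to a hydroxy group, gives a 2.9-fold higher number from compound 1 to compound 4 (0.47 log units; beyond the scatter) and so means weaker inhibition. Among these compounds, this is the first step that isolates this position, and it shows the position responding to this change, though only modestly. Nothing available bears on why the number rises.

On these data alone, whether the step follows from the ring or from its nitrogen stays open. So does the outcome with an amine or a carboxylic acid at this place on the core of compound 1.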